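Removing the methoxymethyl group from compound 2

This account rests on a few compounds, and the source may have more. Where it says the series, first, only, none or still open, it means among the compounds named here.

In an ADME assay on DU-145 cells (Homo sapiens) for cytotoxicity, read by MTT assay, with a stated time of 72 h (a higher number here means a weaker inhibitor, a lower number a stronger inhibitor), compound 1 `COc1ccc(OC)c(C2=C(c3cc(OC)c(OC)c(OC)c3)C(=O)CC2O[SiH2]C(C)(C)C)c1` gives 100 ug/mL. In this assay, going by the values given here, compound 2 `COCOc1cc(C2=C(c3cc(OC)c(OC)c(OC)c3)C(=O)CC2O[SiH2]C(C)(C)C)ccc1OC` gives 34 ug/mL, the lower of the two numbers so far.

Compound 3 `COc1ccc(C2=C(c3cc(OC)c(OC)c(OC)c3)C(=O)CC2O[SiH2]C(C)(C)C)cc1O` carries hydrogen in place of methoxymethyl on an oxygen on an aromatic ring, so that 4-methoxy-3-(methoxymethoxy)phenyl becomes 3-hydroxy-4-methoxyphenyl: hydrogen in place of methoxymethyl on an oxygen on an aromatic ring. Among the compounds with values here, no measured step makes this exact change, and no measured compound yet has the hydroxy group.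

Within the data shown here, only one measured step bears on it, and only indirectly. That step, a 2.9-fold lower number from compound 1 to compound 2 (0.47 log units; beyond the scatter), is modest but beyond the scatter, and it replaces 2,5-dimethoxyphenyl with the same aromatic group that is altered here. One step gives no firm direction for the new change, so the expectation is weak. The expected change in this assay is small and towards a lower number, a 1.7-fold lower number from compound 2 to compound 3 (0.23 log units; within the scatter), and it may not clear the scatter.

For compound 3 the estimated value is 20 ug/mL, with an expected range of 6 ug/mL to 60 ug/mL.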

Compound 3, half-maximal inhibitory concentration: 75 ug/mL
The estimate for compound 3 lay 3.8-fold (0.57 log units) below the measured number, outside the stated range (above it).
By their numbers in this assay, from the lowest: compound 2; then compounds 3 and 1 (each within the scatter of the next).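

In this assay, hydrogen in place of methoxymethyl on the oxygen on the aromatic ring gives a 2.2-fold higher number from compound 2 to compound 3 (0.34 log units; beyond the scatter), so the earlier step, a 2.9-fold lower number from compound 1 to compound 2 (0.47 log units; beyond the scatter), is not extended by exposing the hydroxy group, and the lowest number in the set stays with the methoxymethoxy group of compound 2. The comparison of the free hydroxy compound with the dimethoxy compound, a 1.3-fold lower number from compound 1 to compound 3 (0.12 log units; within the scatter), does not separate 3-hydroxy-4-methoxyphenyl from 2,5-dimethoxyphenyl, so the change of aromatic group without methoxymethyl carries no readable step in these data. Nothing available explains why this oxygen responds to methoxymethyl in this way.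

Still open, going by these compounds, is whether the step follows the methoxymethyl group specifically or would also appear with another group on the same oxygen, such as an ethyl group, a longer ether chain or an acetyl group. Going by these compounds alone, also open is whether an amine in place of the hydroxy group would stay with compound 3 or move towards compound 2, and with only three compounds on one shared core, no trend can be stated for this position.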